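Adding a second chlorine to the urea-capped phenyl ring

This account rests on a few compounds, and the source may have more. Where it says the series, first, only, none or still open, it means among the compounds named here.

Three close relatives share one core and one urea link to a terminal phenyl ring. Compound 1 `CN(C)CCCNc1nc(-c2ccc(NC(=O)Nc3ccc(Cl)cc3Cl)cc2)nc2c(Cl)c(Cl)sc12` carries a dichlorinated terminal ring on a longer side chain and gives 3490 nM in a functional assay on MDA-MB-231 cells (Homo sapiens) for cytotoxicity, read by MTT assay, with a stated time of 72 h; on this read-out higher numbers stand for weaker inhibition and lower numbers for stronger inhibition. Compound 2 `CN(C)CCNc1nc(-c2ccc(NC(=O)Nc3ccc(Cl)cc3)cc2)nc2c(Cl)c(Cl)sc12` gives 870 nM in this assay, and compound 3 `CN(C)CCNc1nc(-c2ccc(NC(=O)Nc3ccccc3Cl)cc2)nc2c(Cl)c(Cl)sc12` gives 1350 nM. On these numbers compound 3 sits second highest of the three, close to compound 2 and further from compound 1. Among the measured compounds shown here, the one step that can be compared in a single place, a 1.6-fold higher number from compound 2 to compound 3 (0.19 log units; within the scatter), moves the chlorine around the ring without a change beyond the scatter.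

Compound 4 `CN(C)CCNc1nc(-c2ccc(NC(=O)Nc3ccc(Cl)cc3Cl)cc2)nc2c(Cl)c(Cl)sc12` takes the next step: chloro in place of hydrogen on an aromatic carbon, so that 2-chlorophenyl becomes 2,4-dichlorophenyl. For the measured compounds named here, no measured step adds a chlorine to an already chlorinated ring here; compound 1, the only dichlorinated relative, differs also in its side chain, so it gives only a hint. The expected step is therefore small, a 1.5-fold higher number from compound 3 to compound 4 (0.17 log units; within the scatter), and compound 4 is estimated at 2000 nM, within 700 nM to 6000 nM.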

Compound 4, half-maximal inhibitory concentration: 3500 nM
For compound 4 the middle estimate is 1.8-fold (0.24 log units) below the measured one; low and high end bracket the measured number.
By their numbers in this assay, from the lowest: compounds 2 and 3 (each within the scatter of the next); then compounds 1 and 4 (each within the scatter of the next).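

On the terminal ring, going from 2-chlorophenyl to 2,4-dichlorophenyl gives a 2.6-fold higher number from compound 3 to compound 4 (0.41 log units; beyond the scatter) in this assay and so weakens inhibition, which the earlier move of one chlorine around the ring did not do beyond the scatter. Coming from the 4-chlorophenyl ring, the same kind of addition gives a 4.0-fold higher number from compound 2 to compound 4 (0.60 log units; beyond the scatter), so both singly chlorinated rings lose inhibition on gaining the second chlorine. With the dichlorinated ring in place, changing the side chain gives a 1.0-fold higher number from compound 1 to compound 4 (0.00 log units; within the scatter), so on this ring the two chain lengths cannot be told apart.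

Nothing available here explains why the second chlorine weakens inhibition. As far as these compounds go, whether a fluorine, methyl or methoxy group in place of that chlorine would give a similar rise remains open.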